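Pyrazoline amides: acyl variation and cell inhibition

This account rests on a few compounds, and the source may have more. Where it says the series, first, only, none or still open, it means among the compounds named here.

Measured so far in a functional assay on NCI-H1975 cells (Homo sapiens) for inhibition, read by sulforhodamine B assay, tested at 10 uM; a lower number here means less inhibition, a higher number more inhibition at the concentration tested (going by the name of the read-out):
compound 1, `CC(=O)N1N=C(c2ccc(N3CCN(C)CC3)cc2)CC1c1ccc(N(C)C)cc1`: -1.9%
compound 2, `COC(=O)CC(=O)N1N=C(c2ccc(N3CCN(C)CC3)cc2)CC1c1ccc(N(C)C)cc1`: -2.2%

Both numbers sit close to zero. For the measured compounds named here, compound 2 stands alongside compound 1 rather than apart from it: the only measured step, a number 0.3 percentage points lower from compound 1 to compound 2 (within the scatter), is within the scatter, so the two compounds show the same, essentially absent, inhibition on the shared core.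

Compound 3, `Cc1ccc(C(=O)N2N=C(c3ccc(N4CCN(C)CC4)cc3)CC2c2ccc(N(C)C)cc2)cc1`, is the next member. It differs from compound 2 by 4-methylphenyl in place of (methoxycarbonyl)methyl on a carbonyl carbon, so the carbonyl now carries an aromatic substituent where the chain stood.

Going by the values given here, no measured step covers an aromatic group on this carbonyl. Among the compounds with values here, the single step that exists, a number 0.3 percentage points lower from compound 1 to compound 2 (within the scatter), changed the chain on the carbonyl without moving the number, and it is the only guide. Given that, the default expectation for compound 3 is a step of about a number 4.2 percentage points higher from compound 2 to compound 3 (within the scatter) in this assay, not beyond the scatter, while allowing a wider range than the two measured values span because the aryl change is untested. Compound 3 is therefore estimated at 2%, with a range from -10% to 18%.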

Compound 3, a percentage reported as inhibition, at one concentration (the size of the read-out at that concentration, not a potency): -0.4%
Compound 3: middle estimate off by 2.4 percentage points, on the high side; measured number inside the range.
By their numbers in this assay, from the lowest: compounds 2, 1 and 3 (each within the scatter of the next).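

On the carbonyl carbon whose other neighbour is the amide-type nitrogen in a ring, the series now includes an aromatic ring as well as chains. In this assay, 4-methylphenyl in place of (methoxycarbonyl)methyl gives one step (a number 1.8 percentage points higher from compound 2 to compound 3 (within the scatter)) and 4-methylphenyl in place of methyl gives another (a number 1.5 percentage points higher from compound 1 to compound 3 (within the scatter)), so the aromatic ring does not set compound 3 apart from either compound with a chain at this position. Nothing beyond these numbers bears on the result.

All three compounds stay close to zero, so the shared core offers no inhibition at this position against which the size of any substituent change could be judged, and a flat result here says nothing about substituents of other kinds. Open, on these data alone, are a free carboxylic acid in place of the methyl ester, an amine on the chain, a longer chain, and a phenyl ring carrying fluorine or methoxy in place of the 4-methyl group, as well as any change to the core away from this carbonyl.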